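Bromo for fluoro on a limit-bound cytotoxicity series

The source may report more compounds than this note shows. Statements on the series, on what has been measured and on what is new or still open speak of the compounds shown alone.

Measured so far:
compound 1, `COc1ccc(-c2cnc(NC(=O)c3cccc([N+](=O)[O-])c3)n2C)cc1`, > 100000 nM
compound 2, `Cn1c(-c2ccccc2F)cnc1NC(=O)c1ccc(F)cc1`, > 100000 nM
compound 3, `CCCCn1c(-c2ccc(OC)cc2)cnc1NC(=O)c1ccc(F)cc1`, > 100000 nM

The three compounds share a core and were tested in a toxicity assay on THP-1 cells (Homo sapiens) for inhibition; on this read-out lower numbers stand for higher toxicity in this test and higher numbers for lower toxicity in this test. Compound 1 reaches only a limit of the assay in this assay, reported as > 100000 nM. Compound 3 likewise stops at a limit, giving > 100000 nM. Among the compounds with values here, compound 2 stands in the same place: its result of > 100000 nM is a limit and not a number, so no compound can be ordered against another here. All that can be said is summed up in the limit of > 100000 nM in this assay, at which 3 of the 3 values shown sit.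

The next compound is compound 4, `Cn1c(-c2ccccc2Br)cnc1NC(=O)c1ccc(F)cc1`. Set against compound 2, the change is bromo in place of fluoro on an aromatic carbon; cut one bond further out it reads 2-fluorophenyl to 2-bromophenyl. Within the data shown here, no measured step between two compounds is available, so nothing shows how this change moves the read-out. With every value shown sitting at a limit, the expected step from compound 2 to compound 4 is none beyond the scatter, a number no higher from compound 2 to compound 4 (the limit leaves the size open). For compound 4 the estimate in this assay is therefore 100000 nM, with a range from 40000 nM to 250000 nM, and it is most likely that only a limit will again be reported.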

Compound 4, half-maximal cytotoxic concentration: > 100000 nM
Compound 4 ended at the assay's limit (the forecaster's own chance of this, stated with the estimate: 85%); the middle value lies on the limit itself.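

In this assay compound 2 and compound 4 both stop at a limit of the assay, so no step can be read for bromo in place of fluoro on an aromatic carbon. The compounds shown leave open whether any change on the shared core brings the read-out to a measurable number: the limit of > 100000 nM in this assay, at which 4 of the 4 values shown sit.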